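A few compounds are considered here, and "the series" means these few. Any claim that something is new, unique, unknown or untested is made for them only; others in the source may bear on it.

Compound 2 `Cc1nc2c3ccccc3ccc2c2nc3c(ccc4ccccc43)c(-c3ccccc3S)c12` stands lowest of the two numbers measured in a functional assay on HeLa cells (Homo sapiens) for cytotoxicity, read by MTT assay, with a stated time of 48 h (a higher number here means a weaker inhibitor, a lower number a stronger inhibitor), where compound 2 gives 3190 nM. Among the compounds with values here, its nearest neighbour is compound 1 `Cc1nc2c3ccccc3ccc2c2nc3c(ccc4ccccc43)c(-c3ccccc3N)c12`, and in this assay compound 1 gives 16200 nM; the single measured step, a 5.1-fold lower number from compound 1 to compound 2 (0.71 log units; beyond the scatter), shows that the group on this carbon moves the number beyond the scatter.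

The next compound, compound 3 `Cc1nc2c3ccccc3ccc2c2nc3c(ccc4ccccc43)c(C)c12`, carries a different change at the same place: methyl in place of 2-sulfanylphenyl on an aromatic carbon, on the aromatic carbon opposite the ring nitrogen. Within the data shown here, no measured step covers removal of the whole 2-sulfanylphenyl; the step from compound 1 to compound 2 only shows that the substituent at this carbon is not indifferent. A higher number is therefore expected for compound 3, with the step of a 3.1-fold higher number from compound 2 to compound 3 (0.50 log units; beyond the scatter) estimated to fall beyond the scatter, broadly back toward the level of compound 1.

Compound 3 is estimated at 10000 nM, within a range from 2500 nM to 40000 nM.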

Compound 3, half-maximal inhibitory concentration: > 80000 nM
Compound 3: only a limit was reported; the forecaster's own chance of this, stated with the estimate: 15%; middle value at least 8.0-fold (0.90 log units) from the limit.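

At this aromatic carbon, the earlier pair showed only that the choice between sulfanyl and amino on the phenyl ring moves the number; replacing the whole substituted phenyl with methyl goes further. In this assay, the change gives an at least 25-fold higher number from compound 2 to compound 3 (1.39 log units; beyond the scatter), and from the other phenyl-bearing compound it gives an at least 4.9-fold higher number from compound 1 to compound 3 (0.69 log units; beyond the scatter). Both phenyl-bearing compounds therefore give a number, while compound 3 gives only a limit of the assay, > 80000 nM, so both steps are minimum sizes: the limit of > 80000 nM in this assay, at which 1 of the 3 values shown sits.

The compounds shown leave open whether the ring alone accounts for the difference from compound 3, or whether its sulfanyl or amino group is also needed. An unsubstituted phenyl, a 2-hydroxyphenyl or a longer alkyl chain at this carbon would separate these readings.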